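This account rests on a few compounds, and the source may have more. Where it says the series, first, only, none or still open, it means among the compounds named here.

In a physicochemical assay for lipophilicity (a lower number here means a more polar compound, a higher number a more lipophilic compound), compound 1 (`C=CC(CCC)OC[n+]1ccn(C)c1/C=N/O`) gives -0.87 and compound 2 (`C#CC(CCC)OC[n+]1ccn(C)c1/C=N/O`) gives -1.1 while compound 3 (`C#CCC(CCC)OC[n+]1ccn(C)c1/C=N/O`) gives -1.17 and so stands within the scatter of both. Compound 4 (`C#CCC(OC[n+]1ccn(C)c1/C=N/O)c1ccccc1`) has phenyl in place of propyl on a saturated chain carbon bound to an oxygen on a saturated carbon and a saturated chain carbon. The measured steps bear on this only loosely, since each exchanges vinyl, ethynyl or propargyl and none replaces propyl (a number 0.23 log units lower from compound 1 to compound 2 (within the scatter) and a number 0.30 log units lower from compound 1 to compound 3 (within the scatter) and a number 0.07 log units lower from compound 2 to compound 3 (within the scatter)). The estimate in this assay is a number 0.07 log units higher from compound 3 to compound 4 (within the scatter) and so no step beyond the scatter is expected. Compound 4 is expected at -1.1 (estimated range -1.5 to -0.7).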

Compound 4, distribution coefficient: -1.05
Compound 4: middle estimate off by 0.05 log units, on the low side, and the stated range covers the measured number.
By their numbers in this assay, from the lowest: compounds 3, 2, 4 and 1 (each within the scatter of the next).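

Phenyl in place of propyl gives a number 0.12 log units higher from compound 3 to compound 4 (within the scatter) in this assay on this saturated chain carbon bound to an oxygen on a saturated carbon and a saturated chain carbon. Unlike the earlier vinyl, ethynyl and propargyl exchanges, this step replaces the propyl itself, and a six-membered aromatic ring of carbon only there stays within the scatter. No supporting data bear on the reason for this result. Open, on these data alone, is whether an amine or a carboxylic acid in place of propyl would also stay within the scatter, and whether phenyl would do so alongside vinyl or ethynyl.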